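Metabolic stability notes: halogenated benzyl series, compound 3

The compounds below may be only part of what the source reports. "The series", "measured", "known", "first", "only" and "open" are said of these compounds alone.

Measured so far:
compound 1 `Brc1cccc2c1nnn2Cc1ccccc1` — 2 mL/min/g
compound 2 `Fc1cccc(Cn2nnc3c(Br)cccc32)c1` — 1.6 mL/min/g

In an ADME assay on microsomes from liver (Rattus norvegicus, strain Wistar) for metabolic stability, tested at 2.5 uM (a higher number here means faster removal of the compound, a lower number slower removal), compound 2 gives 1.6 mL/min/g, the lowest of the two numbers, with compound 1 nearest at 2 mL/min/g. Going by the values given here, the one measured step, a 1.3-fold lower number from compound 1 to compound 2 (0.10 log units; within the scatter), is within the scatter. Compound 3 `Fc1cc(Cn2nnc3c(Br)cccc32)ccc1Cl` differs from compound 2 by chloro in place of hydrogen on an aromatic carbon. Among the compounds with values here, no measured step introduces a chloro group, so the fluoro step from compound 1 to compound 2 is the only guide, and it showed no movement beyond the scatter. For compound 3 the expected step is therefore a 1.1-fold higher number from compound 2 to compound 3 (0.03 log units; within the scatter), nothing beyond the scatter. Compound 3 is estimated at 1.7 mL/min/g, within 0.8 mL/min/g to 3.5 mL/min/g.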

Compound 3, intrinsic clearance in a liver preparation (reported as CLH), per the amount of preparation that the assay uses: 3.1 mL/min/g
The estimate for compound 3 lay 1.8-fold (0.26 log units) below the measured number; the range from low to high includes it.
By their numbers in this assay, from the lowest: compounds 2, 1 and 3 (each within the scatter of the next).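

In this assay, chloro in place of hydrogen on an aromatic carbon, ortho to a fluoro group and para to a large group, gives a 1.9-fold higher number from compound 2 to compound 3 (0.29 log units; within the scatter) and so stays inside the scatter. Going by these compounds alone, this is the first reading at this position, and it shows that chloro is tolerated here with a step no larger than the scatter. Nothing available bears on why the number lies where it does.

In this assay the compounds shown leave open how chloro reads without the fluoro group. They also leave open whether an amine or a carboxylic acid at this position would give a step beyond the scatter.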